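The compounds below may be only part of what the source reports. "The series", "measured", "known", "first", "only" and "open" are said of these compounds alone.

Compound 1 `CCCCCCNC(=O)n1cc(C)c(=O)[nH]c1=O` and compound 2 `CCCCCCNC(=O)n1cc(CC)c(=O)[nH]c1=O` share one core, while compound 3 `CCCCNC(=O)n1ccc(=O)[nH]c1=O` and compound 4 `CCCCCNC(=O)n1ccc(=O)[nH]c1=O` share another; the difference between the two cores is not broken down here. In an assay on HEK293 cells for inhibition of acid ceramidase (Rattus norvegicus), read by LC-MS, with a stated time of 30 min (on this read-out higher numbers stand for weaker inhibition and lower numbers for stronger inhibition), compound 1 gives 1460 nM and compound 2 gives 733 nM. The change methyl in place of hydrogen on a saturated chain carbon bound to an aromatic carbon made a 2.0-fold lower number from compound 1 to compound 2 (0.30 log units; within the scatter). In this assay compound 3 gives 8500 nM, the highest of the three numbers. Compound 4 carries the change (methyl in place of hydrogen on a saturated chain carbon, four bonds along the chain from an amide-type nitrogen), the same kind of change as before but not the same: the earlier one sits on a saturated chain carbon bound to an aromatic carbon, this one on a saturated chain carbon four bonds along the chain from an amide-type nitrogen. In this assay the expected step is a 2.8-fold lower number from compound 3 to compound 4 (0.45 log units; beyond the scatter), somewhat larger than the earlier one. That expectation rests on compound 3 giving 8500 nM while compound 1, with the longer chain, gives 1460 nM. Compound 4 is estimated at 3000 nM, with a range from 1200 nM to 7000 nM.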

Compound 4, half-maximal inhibitory concentration: 2100 nM
Beside the measured number, compound 4's estimate is 1.4-fold (0.15 log units) above it; the range from low to high includes it.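

Methyl in place of hydrogen on a saturated chain carbon, four bonds along the chain from an amide-type nitrogen, gave a 4.0-fold lower number from compound 3 to compound 4 (0.61 log units; beyond the scatter) in this assay. Set beside the earlier methyl step on the other core, this step cannot be told apart from it: the same change on two cores in this assay, a 2.0-fold lower number (0.30 log units; within the scatter) from compound 1 to compound 2 and a 4.0-fold lower number (0.61 log units; beyond the scatter) from compound 3 to compound 4, 2.0-fold (0.31 log units) apart, within the scatter of two such steps. That agrees with a methyl change carrying over between these cores, but it rests on two pairs with the methyl at a different place in each, so it does not show that one fixed effect transfers.

Still open, from the compounds shown here alone, is what a longer chain, or an amine or a carboxylic acid on the chain, would do to the number. Also open, going by these compounds, is how the same methyl change behaves at one and the same place on both cores.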